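This account rests on a few compounds, and the source may have more. Where it says the series, first, only, none or still open, it means among the compounds named here.

Measured in an assay for inhibition of 3-hydroxy-3-methylglutaryl-coenzyme A reductase (Rattus norvegicus) (on this read-out higher numbers stand for weaker inhibition and lower numbers for stronger inhibition), were three compounds:

Compound 1 `Cc1cccc(-c2cc(Cl)cc(Cl)c2/C=C/[C@@H]2C[C@@H](O)CC(=O)O2)c1`: 16 nM
Compound 2 `O=C1C[C@H](O)C[C@@H](/C=C/c2ccccc2-c2ccccc2)O1`: 3000 nM
Compound 3 `O=C1C[C@H](O)CC(CCc2c(Cl)cc(Cl)cc2-c2ccccc2)O1`: 100 nM

Compound 1 has the lowest number of the three. Its nearest neighbour is compound 3, whose number is higher by a margin beyond the scatter; compound 2 lies furthest away, with a far higher number, also well beyond the scatter.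

Compound 4 `Cc1cc(C)cc(-c2cc(Cl)cc(Cl)c2/C=C/[C@@H]2C[C@@H](O)CC(=O)O2)c1` has not yet been measured in this assay. It differs from compound 1 in one place: methyl in place of hydrogen on an aromatic carbon, on the ring that already carries a methyl group, meta to a methyl group and meta to a large group; read one bond further out, the change is from 3-methylphenyl to 3,5-dimethylphenyl. Among the measured compounds shown here, no pair of measured compounds shows this change, so its effect in this assay cannot be read from the data at hand. A second methyl on the same pendant ring is a small addition, and the expectation is a step of a 1.1-fold lower number from compound 1 to compound 4 (0.03 log units; within the scatter) that stays within the usual scatter, with no clear direction. Compound 4 is therefore expected to give about 15 nM, with a range from 5 nM to 50 nM.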

Compound 4, half-maximal inhibitory concentration: 13 nM
Estimate against measurement, compound 4: 1.2-fold (0.06 log units) above; low and high end bracket the measured number.
By their numbers in this assay, from the lowest: compounds 4 and 1 (each within the scatter of the next); then compound 3; then compound 2.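

In this assay, among the compounds shown here, the change of 3-methylphenyl to 3,5-dimethylphenyl gives the first step in this set that can be read at a single place, and that step is a 1.2-fold lower number from compound 1 to compound 4 (0.09 log units; within the scatter) and stays within the scatter. It shows that methyl in place of hydrogen on this aromatic carbon, meta to a large group and meta to a methyl group, leaves a number that cannot be told apart from that of compound 1, so this position of the pendant ring accepts one more heavy atom with no measurable consequence on this read-out. No measurement at hand offers an explanation for this result, and the step therefore stands as an observation only. 

Whether larger or different groups at this carbon, such as an ethyl, a methoxy, a hydroxyl, an amine or a carboxylic acid, would also stay within the scatter remains open, since methyl is the only group shown here. Also open, on these data alone, is what the first methyl contributes. No compound shown pairs compound 1 with its plain phenyl counterpart.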